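Pentyl on Selenium: Two Cores, One Small Step

This account rests on a few compounds, and the source may have more. Where it says the series, first, only, none or still open, it means among the compounds named here.

Measured compounds:
compound 1, `CCCCC[Se]c1nc(NCc2ccccc2)c2ccccc2n1`: 81100 nM
compound 2, `[SeH]c1nc(NCc2ccccc2)c2ccccc2n1`: > 100000 nM
compound 3, `Nc1nc([SeH])nc2ncccc12`: 96600 nM

All three were tested in a functional assay on HTB-54 cells (Homo sapiens) for cytotoxicity, read by MTT assay, with a stated time of 72 h; on this read-out lower numbers stand for stronger inhibition of growth and higher numbers for weaker inhibition of growth. Compound 1 gives 81100 nM. For compound 2 the result is a limit of the assay and not a number, > 100000 nM; it sits at the limit of > 100000 nM in this assay, at which 1 of the 3 values shown sits. Compound 3 gives 96600 nM, and against compound 1 its value lies within the usual scatter. The difference between the core of compound 2 and the core of compound 3 is not broken down here.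

The step from compound 2 to compound 1 is pentyl in place of hydrogen on a selenium; it made an at least 1.2-fold lower number from compound 2 to compound 1 (0.09 log units; that floor lies within the scatter). Compound 4, `CCCCC[Se]c1nc(N)c2cccnc2n1`, has not yet been measured; it differs from compound 3 by pentyl in place of hydrogen on a selenium, the same change at the same kind of place. Compound 3 and compound 4 therefore stand to each other as compound 2 and compound 1 do. Compound 4 is expected to move only little, an estimated step of a 1.2-fold lower number from compound 3 to compound 4 (0.08 log units; within the scatter) in this assay, because the earlier step of an at least 1.2-fold lower number from compound 2 to compound 1 (0.09 log units; that floor lies within the scatter) reaches only a floor that lies within the scatter. The estimate for compound 4 is 80000 nM, expected to fall between 40000 nM and 160000 nM.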

Compound 4, concentration for total growth inhibition: 51000 nM
The estimate for compound 4 lay 1.6-fold (0.20 log units) above the measured number; low and high end bracket the measured number.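

Pentyl in place of hydrogen on a selenium gave a 1.9-fold lower number from compound 3 to compound 4 (0.28 log units; within the scatter) in this assay, so on this second core, as on the first, the step stays inside the usual scatter. Set side by side, the two steps give no firm measure of how well the change carries from one core to the other: the same change on two cores in this assay, an at least 1.2-fold lower number (0.09 log units; that floor lies within the scatter) from compound 2 to compound 1 and a 1.9-fold lower number (0.28 log units; within the scatter) from compound 3 to compound 4; the limit leaves it open whether they differ. What the series shows is that the change, taken to a second core, again produced no step beyond the scatter; it does not show that pentyl truly lowers the number on either core, nor that the size of the step is the same on both.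

The compounds shown leave open whether a longer chain on the selenium would bring a step beyond the scatter on either core. As far as these compounds go, it also remains open whether an amine or a carboxylic acid at the end of such a chain would do so, and whether the two cores would then answer alike.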